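The source may hold more compounds than are shown below. What is called first, only, known or untested is meant among the compounds shown, and "the series" means these compounds.

Series built on the shared core of compound 1 `O=C(CSc1snnc1-c1ccc(Br)cc1Br)Nc1cccnc1Cl`, with the group on the amide-type nitrogen varied. In an ADME assay on MT4 cells (Homo sapiens) for cytotoxicity, read by MTT assay, with a stated time of 5 days (a lower number here means that less compound is tolerated, a higher number that more compound is tolerated), compound 1 gives only a limit of the assay, > 240000 nM (the limit of > 240000 nM in this assay, at which 1 of the 3 values shown sits). Compound 2 `Cc1cccc(NC(=O)CSc2snnc2-c2ccc(Br)cc2Br)c1C` gives 241000 nM in this assay. Compound 3 `Cc1ccc(NC(=O)CSc2snnc2-c2ccc(Br)cc2Br)cc1` gives 24000 nM in this assay, the lowest of the two numbers; the nearest number lies a 10-fold lower number from compound 2 to compound 3 (1.00 log units; beyond the scatter). Compound 4 `COC(=O)c1ccsc1NC(=O)CSc1snnc1-c1ccc(Br)cc1Br` brings (3-(methoxycarbonyl)thiophen-2-yl in place of 4-methylphenyl on an amide-type nitrogen). The steps bearing on this change are a 10-fold lower number from compound 2 to compound 3 (1.00 log units; beyond the scatter) and an at least 10-fold lower number from compound 1 to compound 3 (1.00 log units; beyond the scatter), both of which leave 4-methylphenyl with the lowest number. Leaving 4-methylphenyl is therefore expected to raise the number in this assay, an upward step a 5.0-fold higher number from compound 3 to compound 4 (0.70 log units; beyond the scatter). Compound 4 is expected at 120000 nM, in a range from 30000 nM to 300000 nM.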

Compound 4, half-maximal cytotoxic concentration: > 227000 nM
Compound 4: no number, only a limit; the forecaster's own chance of this, stated with the estimate: 30%; middle value at least 1.8-fold (0.27 log units) away from the limit.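

In this assay, 3-(methoxycarbonyl)thiophen-2-yl on the amide-type nitrogen gives an at least 9.4-fold higher number from compound 3 to compound 4 (0.97 log units; beyond the scatter), so a five-membered aromatic ring also leaves 4-methylphenyl with the lowest number. Compound 4 gives only a limit, not a number: the limit of > 227000 nM in this assay, at which 1 of the 4 values shown sits. Of the four groups shown, only 4-methylphenyl gives a low number, and the steps linking compound 4 with compound 1 and compound 2 cannot be read.

From the compounds shown here alone, whether the low number of compound 3 is specific to 4-methylphenyl stays open. Plain phenyl, 4-methoxyphenyl, or a thiophene carrying a carboxylic acid in place of the methoxycarbonyl would test this.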